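Allyl-Substituted Diketopiperazine Analogues: From Inactive to Unknown

A few compounds are considered here, and "the series" means these few. Any claim that something is new, unique, unknown or untested is made for them only; others in the source may bear on it.

Compound 1 `COc1ccccc1/C=c1\c(=O)[nH]/c(=C/c2cccc(Cl)c2Cl)c(=O)n1C` gives 200 nM in a functional assay on MCF7 cells (Homo sapiens) for cytotoxicity, read by CCK-8 assay, with a stated time of 72 h; a lower number here means a stronger inhibitor, a higher number a weaker inhibitor.
Compound 2 `C=CCn1c(=O)/c(=C\c2ccc(Cl)c(Cl)c2)[nH]c(=O)/c1=C\c1ccccc1` gives "not active" (no number reported) in this assay.
Compound 3 `C=CCn1c(=O)/c(=C\c2ccc(F)c(Br)c2)[nH]c(=O)/c1=C\c1ccccc1OC` gives "not active" (no number reported) in this assay.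

Of the compounds shown here, three sharing the same core have been measured. Compound 1 is the only one of them with a number in this assay. Compound 3 stands without a single number, and compound 2 is the one further entry that also lacks a number. Compound 3 carries the allyl group and the 2-methoxyphenyl group, and in this assay it is recorded as "not active" (no number reported).

Compound 4 `C=CCn1c(=O)/c(=C\c2ccccc2C(F)(F)F)[nH]c(=O)/c1=C\c1ccccc1OC` has not yet been measured. It differs from compound 3 in one place: 2-(trifluoromethyl)phenyl in place of 3-bromo-4-fluorophenyl on a double-bonded chain carbon bound to an aromatic carbon. Among the measured compounds shown here, no measured pair that differs in exactly this way is available, so the size of this step in this assay cannot be taken from the data. Given that compound 3 and compound 2, the two compounds that keep the allyl group, both return no number, the expectation is for no clear change beyond the scatter, with a substantial chance that compound 4 again returns only a limit rather than a number. For compound 4 the estimated value in this assay is 30000 nM, expected to fall between 5000 nM and 150000 nM.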

Compound 4, half-maximal inhibitory concentration: 6500 nM
Compound 4: middle estimate off by 4.6-fold (0.66 log units), on the high side; low and high end bracket the measured number.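

No step can be read from compound 3 to compound 4: in this assay compound 3 has no number, while compound 4 gives 6500 nM. The compounds shown leave open how far 2-(trifluoromethyl)phenyl in place of 3-bromo-4-fluorophenyl shifts this read-out. Nothing shown here bears on a cause for the result.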